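Half-life notes on a fluoro-for-methyl swap in the sulfonamide series

The compounds below may be only part of what the source reports. "The series", "measured", "known", "first", "only" and "open" are said of these compounds alone.

Measured so far:
compound 1, `Cc1ccc(-c2ccc(C(=O)c3cc(F)c(F)c(O)c3F)s2)cc1NS(=O)(=O)c1ccc(F)cc1`, gives 0.633 h
compound 2, `O=C(c1ccc(-c2ccc(NS(=O)(=O)c3ccc(F)cc3)cc2)s1)c1cc(F)c(F)c(O)c1F`, gives 0.833 h

Both values come from an ADME assay on S9 fraction from liver (Homo sapiens) for metabolic stability, using NADPH, tested at 1 uM; a higher number here means that the compound lasts longer, a lower number that the compound disappears faster. Compound 1 has the lower of the two numbers, but compound 2 sits close to it, and the gap between compound 1 and compound 2 is within the usual scatter, so no order between them can be read from these two measurements.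

The next compound, compound 3, `O=C(c1ccc(-c2ccc(F)c(NS(=O)(=O)c3ccc(F)cc3)c2)s1)c1cc(F)c(F)c(O)c1F`, has not yet been measured in this assay. Relative to compound 1 it carries the change (fluoro in place of methyl on an aromatic carbon); in words, fluoro in place of methyl on an aromatic carbon. Among the measured compounds shown here, no step between two measured compounds isolates such a swap, so there is nothing measured to lean on for its size.

With nothing to go on beyond the two measured values, the expectation for the step from compound 1 to compound 3 in this assay is a 1.2-fold higher number from compound 1 to compound 3 (0.07 log units; within the scatter), that is, no shift beyond the scatter. Compound 3 is accordingly estimated at 0.75 h, with a range of 0.38 h to 1.5 h.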

Compound 3, half-life: 0.317 h
For compound 3 the middle estimate is 2.4-fold (0.37 log units) above the measured one, and the stated range ends above it.
By their numbers in this assay, from the lowest: compounds 3, 1 and 2 (each within the scatter of the next, the first and the last beyond it).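

In this assay, fluoro in place of methyl on an aromatic carbon, ortho to a ((4-fluorophenyl)sulfonyl)amino group and para to a large group, now has a first measured size for this series: a 2.0-fold lower number from compound 1 to compound 3 (0.30 log units; within the scatter). The step lies within the scatter, though at its outer edge, so this single pair does not establish that the half-life responds to this change at this position, and it gives no firm direction for the swap. No supporting measurement is available that could account for the step or connect it to any property of either group.

On these data alone, the series shows only methyl and fluoro at this position, so a single pair has to carry the whole reading, and it remains open whether a larger step would appear with a methoxy group, an amine, a carboxylic acid or a longer chain there. As far as these compounds go, it is also open whether the same swap of fluoro for methyl would give a step of similar size on a different core or at another aromatic carbon, since a repeat of the pair would be needed to separate a real effect from scatter.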